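The source may report more compounds than this note shows. Statements on the series, on what has been measured and on what is new or still open speak of the compounds shown alone.

In a functional assay on the whole organism (strain Jcl:SD) for inhibition, with Rattus norvegicus as the target, with stated times of 3 min and 3 h, at a dose of 1 mg/kg by the intravenous route (on this read-out higher numbers stand for more inhibition at the one dose given (going by the name of the read-out) and lower numbers for less inhibition), compound 2 `CNCc1cc(-c2cccnc2F)n(S(=O)(=O)c2cccnc2)c1` gives 96%, the lower of the two values, while compound 1 `CNCc1cc(-c2cccnc2F)n(S(=O)(=O)c2cccc(C#N)c2)c1` gives 99%; the step of a number 3 percentage points lower from compound 1 to compound 2 (within the scatter) lies within the scatter. Compound 3 `CNCc1cc(-c2ccncc2F)n(S(=O)(=O)c2cccnc2)c1` differs from compound 2 by 3-fluoropyridin-4-yl in place of 2-fluoropyridin-3-yl on an aromatic carbon. Going by the values given here, no measured step touches this position; the one step known, from compound 1 to compound 2, concerns the group on the sulfonyl sulfur and was small. With the two measured numbers level within the scatter, the expected step of a number 4 percentage points lower from compound 2 to compound 3 (within the scatter) is none beyond the scatter, and compound 3 is estimated at 92%, within 70% to 100%.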

Compound 3, a percentage reported as inhibition, in the whole organism at one dose (the size of the read-out at that dose, not a potency): 48%
The estimate for compound 3 lay 44 percentage points above the measured number; measured number below the stated range.
By their numbers in this assay, from the lowest: compound 3; then compounds 2 and 1 (each within the scatter of the next).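

In this assay, the group on the aromatic carbon next to the ring nitrogen proves far from indifferent: replacing 2-fluoropyridin-3-yl with 3-fluoropyridin-4-yl gives a number 48 percentage points lower from compound 2 to compound 3 (beyond the scatter), although both groups hold the same atoms. The arrangement of those atoms within this group therefore matters at this position, which the earlier step, confined to the group on the sulfonyl sulfur, could not show. No measurement available here accounts for the drop. Going by these compounds, it remains open whether the same loss would appear with 3-cyanophenyl on the sulfonyl sulfur, and how a plain phenyl or a 2-chloropyridin-3-yl would read at this position.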